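This account rests on a few compounds, and the source may have more. Where it says the series, first, only, none or still open, it means among the compounds named here.

Working notes on the series. In a functional assay on HCT-116 cells (Homo sapiens) for antiproliferative activity, read by MTT assay, with a stated time of 72 h (a higher number here means a weaker inhibitor, a lower number a stronger inhibitor), compound 3 `CCN(CC)CCNC(=O)Nc1nc2ccc(-c3cnc(Cl)c(NS(=O)(=O)c4ccc(F)cc4)c3)cc2s1` gives 920 nM, the lowest of the two numbers shown. Compound 1 `COc1ncc(-c2ccc3nc(NC4CC4)sc3c2)cc1NS(=O)(=O)c1ccc(F)cc1` gives 1560 nM, which sits within the scatter of compound 3. Compound 2 `CCCNc1nc2ccc(-c3cnc(Cl)c(NS(=O)(=O)c4ccc(F)cc4)c3)cc2s1` gives only a limit, > 20000 nM. For the measured compounds named here, the step of an at least 21-fold lower number from compound 2 to compound 3 (1.33 log units; beyond the scatter) is the one measured change, and it is large, though it rests on the limit (the limit of > 20000 nM in this assay, at which 1 of the 3 values shown sits).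

Compound 4 `O=S(=O)(Nc1cc(-c2ccc3nc(NC4CC4)sc3c2)cnc1Cl)c1ccc(F)cc1` is the next to be measured in this assay. The change from compound 3 is cyclopropyl in place of (2-(diethylamino)ethyl)carbamoyl on a nitrogen on an aromatic ring. It reverses the measured step: the (2-(diethylamino)ethyl)carbamoyl that separates compound 3 from compound 2 is removed, and a cyclopropyl takes its place. Going by the values given here, the only measured step that bears on it, an at least 21-fold lower number from compound 2 to compound 3 (1.33 log units; beyond the scatter), points to a higher number for compound 4. Against that, compound 1 carries the same cyclopropyl on the nitrogen on an aromatic ring and gives 1560 nM, within the scatter of compound 3. Among the compounds with values here, compound 1 and compound 4 differ elsewhere on the shared core, and no step between them is measured. The expectation for compound 4 is therefore a moderate rise, a 4.3-fold higher number from compound 3 to compound 4 (0.64 log units; beyond the scatter), to an estimated 4000 nM with a range from 1200 nM to 15000 nM.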

Compound 4, half-maximal inhibitory concentration: 5750 nM
Beside the measured number, compound 4's estimate is 1.4-fold (0.16 log units) below it; the range from low to high includes it.
By their numbers in this assay, from the lowest: compounds 3 and 1 (each within the scatter of the next); then compound 4. At a limit, above all of these: compound 2.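

In this assay, the nitrogen on an aromatic ring now has a second comparison with the chloro kept in place: a 6.3-fold higher number from compound 3 to compound 4 (0.80 log units; beyond the scatter), so the (2-(diethylamino)ethyl)carbamoyl gives the lower number against cyclopropyl as well as against propyl. Cyclopropyl in place of propyl on that nitrogen also matters, an at least 3.4-fold lower number from compound 2 to compound 4 (0.54 log units; beyond the scatter), although this step can only be read as a bound, as compound 2 gives a limit and not a number: the limit of > 20000 nM in this assay, at which 1 of the 4 values shown sits. The aromatic carbon also comes into view for the first time: with cyclopropyl kept on the nitrogen, chloro in place of methoxy gives a 3.7-fold higher number from compound 1 to compound 4 (0.57 log units; beyond the scatter), so the change on that carbon is beyond the scatter.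

The compounds shown do not separate the carbamoyl from the diethylamino part of the larger group, a question that a plain ethylcarbamoyl or a 2-(diethylamino)ethyl directly on the nitrogen would address. On these data alone, it also remains open whether the (2-(diethylamino)ethyl)carbamoyl gives a similar step with methoxy on the aromatic carbon, and how a fluoro or a methyl there would read.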